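The source may report more compounds than this note shows. Statements on the series, on what has been measured and on what is new or still open speak of the compounds shown alone.

Values so far in a functional assay on HepG2 cells (Homo sapiens) for antiproliferative activity, read by MTT assay, with a stated time of 48 h; a higher number here means a weaker inhibitor, a lower number a stronger inhibitor
- compound 1 `COc1ccc(C2OC(c3ccc4ccccc4c3)=NN2C(C)=O)cc1` gives 3.6 ug/mL
- compound 2 `CC(=O)N1N=C(c2ccc3ccccc3c2)OC1c1cccc(Br)c1` gives 1.68 ug/mL
- compound 3 `CC(=O)N1N=C(c2ccc3ccccc3c2)OC1c1cccnc1` gives 2.86 ug/mL

Compound 3 cannot be ranked against the other two. The steps of a 1.3-fold lower number from compound 1 to compound 3 (0.10 log units; within the scatter) and a 1.7-fold higher number from compound 2 to compound 3 (0.23 log units; within the scatter) both stay within the scatter. Among the measured compounds shown here, only the step of a 2.1-fold lower number from compound 1 to compound 2 (0.33 log units; beyond the scatter) goes beyond it, and modestly. Compound 4 `CC(=O)N1N=C(c2ccc3ccccc3c2)OC1c1ccncc1` has the same atoms as compound 3, joined differently (pyridin-4-yl in place of pyridin-3-yl on a saturated ring carbon), with pyridin-4-yl in place of pyridin-3-yl on a saturated ring carbon. Even replacing 4-methoxyphenyl with pyridin-3-yl at this carbon changed little, as the step (a 1.3-fold lower number from compound 1 to compound 3 (0.10 log units; within the scatter)) shows. For the measured compounds named here, no measured pair tests a move within the pyridine itself. So in this assay no step beyond the scatter is expected (estimated: a 1.0-fold lower number from compound 3 to compound 4 (0.01 log units; within the scatter)). For compound 4 the estimated value is 2.8 ug/mL (expected range 1.4 ug/mL to 5.5 ug/mL).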

Compound 4, half-maximal inhibitory concentration: 2.17 ug/mL
Compound 4: the middle estimate sits 1.3-fold (0.11 log units) above what was measured, within the range that was stated.
By their numbers in this assay, from the lowest: compounds 2, 4, 3 and 1 (each within the scatter of the next, the first and the last beyond it).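

In this assay, among the compounds shown here, this is the first pair that tests a change within the pyridine itself, and swapping pyridin-3-yl for pyridin-4-yl on the saturated ring carbon gives no readable difference (a 1.3-fold lower number from compound 3 to compound 4 (0.12 log units; within the scatter)). Compound 4 also cannot be separated from the bromo or methoxy compounds (a 1.3-fold higher number from compound 2 to compound 4 (0.11 log units; within the scatter); a 1.7-fold lower number from compound 1 to compound 4 (0.22 log units; within the scatter)), as both steps stay within the scatter. No measurement on hand offers an explanation for these small differences.

Still open, going by these compounds, is whether an amine or a carboxylic acid on the pyridine, or a longer chain in place of the acetyl group, would produce a step clearly beyond the scatter.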